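The compounds below may be only part of what the source reports. "The series", "measured", "known", "first", "only" and "open" are said of these compounds alone.

In a functional assay on MGC-803 cells (Homo sapiens) for cytotoxicity, read by MTT assay, with a stated time of 72 h (on this read-out lower numbers stand for stronger inhibition and higher numbers for weaker inhibition), compound 1 `CN(C)c1ccc(C=C2C(=O)N(c3ccc(Cl)cc3)N(c3ccc(Cl)cc3)C2=O)cc1` gives 80200 nM and compound 2 `O=C1C(=C/C=C/c2ccccc2)C(=O)N(c2ccc(Cl)cc2)N1c1ccc(Cl)cc1` gives 5100 nM, the lower of the two numbers. Compound 3 `O=C1C(=Cc2c[nH]c3ccccc23)C(=O)N(c2ccc(Cl)cc2)N1c1ccc(Cl)cc1` remains unmeasured and departs from compound 2 by one change on a double-bonded chain carbon bound to a double-bonded ring carbon: 1H-indol-3-yl in place of 2-phenylethenyl on a double-bonded chain carbon bound to a double-bonded ring carbon. Among the measured compounds shown here, the only measured step at this place, a 16-fold lower number from compound 1 to compound 2 (1.20 log units; beyond the scatter), is large, so a sizeable move is possible, but it does not fix the direction for 1H-indol-3-yl. A moderate rise from the lower of the two numbers is expected, namely a 2.4-fold higher number from compound 2 to compound 3 (0.37 log units; beyond the scatter). For compound 3 the estimate is 12000 nM, with an expected range from 2500 nM to 55000 nM.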

Compound 3, half-maximal inhibitory concentration: 21800 nM
Beside the measured number, compound 3's estimate is 1.8-fold (0.26 log units) below it; measured number inside the range.
By their numbers in this assay, from the lowest: compound 2; then compound 3; then compound 1.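

In this assay, 1H-indol-3-yl falls short of 2-phenylethenyl at this place, with a 4.3-fold higher number from compound 2 to compound 3 (0.63 log units; beyond the scatter), yet improves on 4-(dimethylamino)phenyl, with a 3.7-fold lower number from compound 1 to compound 3 (0.57 log units; beyond the scatter). The lower number relative to compound 1 therefore does not depend on 2-phenylethenyl alone, although 2-phenylethenyl remains the best of the three groups shown. No evidence is available to explain this order. From the compounds shown here alone, whether a longer chain, such as 4-phenylbuta-1,3-dienyl, or a simple amine on this chain carbon would give a lower number stays open.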